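The source may report more compounds than this note shows. Statements on the series, on what has been measured and on what is new or still open speak of the compounds shown alone.

Compound 2 (`Oc1ccc(-c2nnc(Nc3csc(-c4ccccc4)c3)s2)cc1`): 26000 nM
Compound 1 (`COc1ccc(-c2nnc(Nc3csc(-c4ccc(C)cc4)c3)s2)cc1`): "not determined" (no result reported)

For the measured compounds named here, in a functional assay on Hs 683 cells (Homo sapiens) for inhibition, read by colorimetric assay and MTT assay, with a stated time of 72 h (a higher number here means a weaker inhibitor, a lower number a stronger inhibitor), compound 2 gives 26000 nM, the only number in hand; in this assay compound 1 is recorded as "not determined" (no result reported), so no result was obtained there. Compound 3 (`Cc1ccc(-c2cc(Nc3nnc(-c4ccc(O)cc4)s3)cs2)cc1`) differs from compound 2 in one place: methyl in place of hydrogen on an aromatic carbon. Going by the values given here, no measured pair shows what this change does, so the expected step is small, a 1.0-fold lower number from compound 2 to compound 3 (0.02 log units; within the scatter) in this assay, with no direction beyond the scatter. For compound 3 the estimate in this assay is 25000 nM, expected to fall between 9000 nM and 70000 nM.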

Compound 3, half-maximal inhibitory concentration: 17000 nM
Compound 3: middle estimate off by 1.5-fold (0.17 log units), on the high side; the measured number falls inside the stated range.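

In this assay, the step is a 1.5-fold lower number from compound 2 to compound 3 (0.18 log units; within the scatter) for the change from phenyl to 4-methylphenyl. This first measured pair at this place shows that a methyl para to a large group leaves the number within the scatter, so the two compounds cannot be ranked. No evidence is available that bears on this result.

A single small group at one position says little about the position as a whole. Going by these compounds, whether an amine, a carboxylic acid or a longer chain here would give a step beyond the scatter remains open.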